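Two compounds measured for paw-edema inhibition and an untested analogue

A few compounds are considered here, and "the series" means these few. Any claim that something is new, unique, unknown or untested is made for them only; others in the source may bear on it.

Compound 1 `N#Cc1ccc(/N=c2\c(C#N)c3n(c(=O)n2-c2ccccc2)CCC3)cc1` and compound 2 `N#CC1=C(NCCN)N(c2ccccc2)C(=O)N2CCCC12` were both examined in a functional assay on the whole organism (strain albino) for inhibition, with Rattus norvegicus as the target, read by paw edema, with a stated time of 4 h, at a dose of 0.029 mmol/kg by the oral route; on this read-out higher numbers stand for more inhibition at the one dose given (going by the name of the read-out) and lower numbers for less inhibition. Compound 1 gives 0.86%. Compound 2 gives 0.61%, which places it at the bottom of the two numbers shown, although the gap to compound 1 is within the scatter. Compound 3 `CCO/C=N/C1=C(C#N)C2CCCN2C(=O)N1c1ccccc1` has not yet been measured in this assay; it differs from compound 2 by a group of 5 heavy atoms (3 carbon, 1 nitrogen, 1 oxygen; no ring) in place of a group of 4 heavy atoms (2 carbon, 2 nitrogen; no ring), on a double-bonded ring carbon. Since both measured values sit near zero, the step of a number 0.4 percentage points higher from compound 2 to compound 3 (within the scatter) is expected to be none beyond the scatter. Compound 3 is therefore estimated at 1%, with a range from -5% to 8%.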

Compound 3, a percentage reported as inhibition, in the whole organism at one dose (the size of the read-out at that dose, not a potency): 0.18%
Estimate against measurement, compound 3: 0.8 percentage points above, within the range that was stated.
By their numbers in this assay, from the lowest: compounds 3, 2 and 1 (each within the scatter of the next).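

With the (2-aminoethyl)amino group replaced on the double-bonded ring carbon by a group that has no hydrogen-bond donors, this assay shows a number 0.4 percentage points lower from compound 2 to compound 3 (within the scatter). This pair therefore gives no sign that the two groups differ at this position at the one dose tested. No measurement at hand offers an explanation for this result. Going by these compounds, whether a carboxylic acid or a longer amine chain at this carbon would give inhibition clearly beyond the scatter remains open. So does whether these compounds would separate at another dose.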